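Imidazolylalkyl guanidines: sulfur in one imidazole arm

A few compounds are considered here, and "the series" means these few. Any claim that something is new, unique, unknown or untested is made for them only; others in the source may bear on it.

Measured so far:
Compound 1, `N=C(NCCCCc1c[nH]cn1)NCCCc1c[nH]cn1` — in an assay on cardiac atrium with histamine H2 receptor (Cavia porcellus) as the target (on this read-out lower numbers stand for smaller maximal responses and higher numbers for larger maximal responses), compound 1 gives 85.5%.
Compound 2, `CC1=NN(c2ccc([N+](=O)[O-])cc2)C(=O)C1[N+](=O)[O-].N=C(NCCCc1c[nH]cn1)NCCCc1c[nH]cn1` — in this assay compound 2 gives 100%.

Compound 1 stands lowest of the two; compound 2 lies higher, by a gap beyond the usual scatter. Compound 3, `N=C(NCCCc1c[nH]cn1)NCCSCc1c[nH]cn1`, is not yet measured. It differs from compound 1 thus: ((1H-imidazol-4-yl)methyl)sulfanyl in place of 2-(1H-imidazol-4-yl)ethyl on a saturated chain carbon, two bonds along the chain from an amine nitrogen. For the measured compounds named here, no step between measured compounds covers such a change, so the expectation rests on compound 1 alone; a small rise, or none beyond the scatter, is expected, as a number 4.5 percentage points higher from compound 1 to compound 3 (within the scatter). For compound 3 the maximal response in this assay is estimated at 90%, within 72% to 100%.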

Compound 3, largest response reached (reported as maximal response), in percent of the reference or control that the assay uses: 95%
The estimate for compound 3 lay 5 percentage points below the measured number; low and high end bracket the measured number.
By their numbers in this assay, from the lowest: compounds 1, 3 and 2 (each within the scatter of the next, the first and the last beyond it).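

In this assay, ((1H-imidazol-4-yl)methyl)sulfanyl in place of 2-(1H-imidazol-4-yl)ethyl at this position gives a number 9.5 percentage points higher from compound 1 to compound 3 (within the scatter), so the read-out does not separate the two arms. For the compounds shown here, this is the first sign that a sulfur atom in this arm can be accommodated without a change beyond the scatter. No measurement in hand bears on the reason.

Still open, as far as these compounds go, is whether a longer chain in the sulfur-bearing arm would keep the maximal response in this assay. The same question holds for a phenyl ring in place of its imidazole.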